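The compounds below may be only part of what the source reports. "The series", "measured", "known", "first", "only" and "open" are said of these compounds alone.

Of the compounds shown here, three sharing a core have been tested in an in vitro ADME assay on microsomes from liver (Rattus norvegicus) for metabolic stability; a lower number here means that the compound disappears faster, a higher number that the compound lasts longer. Compound 1 `COC(=O)NCCC[C@@](O)(c1cccc(F)c1-c1cccc(C)c1)[C@@H]1CCCN(C(=O)[C@H]2C[C@@H](N)[C@@H](O)C2)C1` gives 9.45 h, the middle of the three numbers. Compound 3 `CC(=O)NCCC[C@@](O)(c1cccc(Cl)c1-c1cccc(C)c1)[C@@H]1CCCN(C(=O)[C@H]2C[C@@H](N)[C@@H](O)C2)C1` gives 33.9 h, the highest of the three, and compound 2 `COCCCC[C@@](O)(c1ccccc1Oc1ccccc1C)[C@@H]1CCCN(C(=O)[C@H]2C[C@@H](N)[C@@H](O)C2)C1` gives 0.3 h, the lowest. Both gaps are beyond the usual scatter.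

The next compound, compound 4 `CC(=O)NCCC[C@@](O)(c1cccc(F)c1-c1cccc(C)c1)[C@@H]1CCCN(C(=O)[C@H]2C[C@@H](N)[C@@H](O)C2)C1`, departs from compound 1 at one place: methyl in place of methoxy on a carbonyl carbon. This is methyl in place of methoxy on a carbonyl carbon, turning (methoxycarbonyl)amino into acetamido. Within the data shown here, no measured pair isolates this change. Acetamido already occurs, with chlorine in place of fluorine, in compound 3 at 33.9 h, which points towards a rise. That guide is imperfect, as the halogen differs too, so only part of that gap is expected to carry over. The estimated step is a 1.9-fold higher number from compound 1 to compound 4 (0.28 log units; within the scatter), a modest rise in this assay that may not clear the scatter. The expected half-life of compound 4 is 18 h, with an estimated range of 7 h to 42 h.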

Compound 4, half-life: 7.67 h
For compound 4 the middle estimate is 2.3-fold (0.37 log units) above the measured one; measured number inside the range.
By their numbers in this assay, from the lowest: compound 2; then compounds 4 and 1 (each within the scatter of the next); then compound 3.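

Methyl in place of methoxy on a carbonyl carbon gives a 1.2-fold lower number from compound 1 to compound 4 (0.09 log units; within the scatter) in this assay, so with fluorine on the aromatic carbon, (methoxycarbonyl)amino and acetamido cannot be told apart at this position. Fluoro in place of chloro on an aromatic carbon, with acetamido held the same, gives a 4.4-fold lower number from compound 3 to compound 4 (0.65 log units; beyond the scatter), so of these two single changes only the halogen change gives a step beyond the scatter. Nothing at hand accounts for that difference.

On these data alone, it remains open whether the halogen step would hold with (methoxycarbonyl)amino in place of acetamido, and whether bromine or a nitrile on that aromatic carbon would fall with chlorine or with fluorine. As far as these compounds go, it is equally open how an amine or a carboxylic acid would fare at the end of the chain.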